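The source may hold more compounds than are shown below. What is called first, only, known or untested is meant among the compounds shown, and "the series" means these compounds.

Three members of the series have been run in a functional assay on HL-60 cells (Homo sapiens) for cytotoxicity, read by MTT assay, with a stated time of 72 h; a higher number here means a weaker inhibitor, a lower number a stronger inhibitor. Compound 1 `COCOc1cc(/C=C/C(=O)OCC(=O)Nc2ccc(Cl)cc2)ccc1OCc1ccccc1` gives only a limit there, > 200000 nM. Compound 2 `COc1ccc(NC(=O)COC(=O)/C=C/c2cc(OC)c(OCc3ccc(Cl)c(Cl)c3)c(OC)c2)cc1` likewise returns a limit, > 200000 nM. Going by the values given here, compound 3 `COCOc1ccc(/C=C/C(=O)N2CCN(Cc3ccc(Cl)c(Cl)c3)CC2)cc1OCOC` is the one member with a number, 31000 nM. Compound 1 thus stands at the limit of > 200000 nM in this assay, at which 2 of the 3 values shown sit, and only compound 3 falls inside the measured range. Among the compounds with values here, no pair of these three differs in a single place, so no step is measured. Compound 4 `COCOc1cc(/C=C/C(=O)OCC(=O)NCc2ccco2)ccc1OCc1ccccc1` carries (furan-2-yl)methyl in place of 4-chlorophenyl on an amide-type nitrogen. The change sits on the amide-type nitrogen whose other neighbour is the carbonyl carbon, and nothing measured bears on it. The step from compound 1 to compound 4 is expected to be a number no higher from compound 1 to compound 4 (the limit leaves the size open), none beyond the scatter. Compound 4 is estimated at 200000 nM, within 60000 nM to 600000 nM, and most likely again only a limit.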

Compound 4, half-maximal inhibitory concentration: 82200 nM
Beside the measured number, compound 4's estimate is 2.4-fold (0.39 log units) above it; the range from low to high includes it.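

In this assay, (furan-2-yl)methyl in place of 4-chlorophenyl on the amide-type nitrogen gives an at least 2.4-fold lower number from compound 1 to compound 4 (0.38 log units; beyond the scatter), the first step measured in the series. Going by these compounds alone, this shows that the read-out responds to the group on this nitrogen, which no earlier pair could show. The full size of the step stays open, with compound 1 given only as a limit of the assay: the limit of > 200000 nM in this assay, at which 2 of the 4 values shown sit.

The compounds shown leave open whether the furan ring or the methyl link to the nitrogen carries the step. A 4-chlorobenzyl group on this nitrogen would separate the two.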